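From 2-fluorophenyl to 2-fluoropyridin-3-yl

The compounds below may be only part of what the source reports. "The series", "measured", "known", "first", "only" and "open" are said of these compounds alone.

In an ADME assay (liver) for metabolic stability, with Liver microsome (Rattus norvegicus) as the target, using microsomes (on this read-out higher numbers stand for fast clearance and lower numbers for slow clearance), compound 1 `c1ccc([C@H](Nc2nnc(-c3c[nH]c4ncccc34)o2)C2CC2)cc1` gives 31 mL.min-1.g-1. Compound 2 `Fc1ccccc1[C@H](Nc1nnc(-c2c[nH]c3ncccc23)o1)C1CC1` gives 63 mL.min-1.g-1, the higher of the two numbers, so it is the faster cleared of the pair. Going by the values given here, the only measured step, a 2.0-fold higher number from compound 1 to compound 2 (0.31 log units; beyond the scatter), comes from fluoro in place of hydrogen on an aromatic carbon.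

Compound 3 `Fc1ncccc1[C@H](Nc1nnc(-c2c[nH]c3ncccc23)o1)C1CC1` differs from compound 2 in one group: 2-fluoropyridin-3-yl in place of 2-fluorophenyl on a saturated chain carbon bound to a nitrogen on an aromatic ring and a saturated ring carbon. Among the compounds with values here, no measured step tests this exchange, so the fluoro step bears on it only as a guide to how large a single change can be in this small set. A shift of similar or smaller size is expected, towards a lower number, although that direction is a judgement that the two measured compounds cannot confirm. The expected change is a 1.8-fold lower number from compound 2 to compound 3 (0.26 log units; within the scatter). In this assay, compound 3 is estimated at 35 mL.min-1.g-1, with an expected range of 16 mL.min-1.g-1 to 70 mL.min-1.g-1.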

Compound 3, intrinsic clearance in microsomes: 80 mL.min-1.g-1
For compound 3 the middle estimate is 2.3-fold (0.36 log units) below the measured one; measured number outside the range, above it.
By their numbers in this assay, from the lowest: compound 1; then compounds 2 and 3 (each within the scatter of the next).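

Swapping 2-fluorophenyl for 2-fluoropyridin-3-yl on this saturated chain carbon gives a 1.3-fold higher number from compound 2 to compound 3 (0.10 log units; within the scatter) in this assay, so compound 2 and compound 3 cannot be told apart on this read-out, even though the new ring brings a ring nitrogen and a hydrogen-bond acceptor. The comparison with the plain phenyl group is clearer, with a 2.6-fold higher number from compound 1 to compound 3 (0.41 log units; beyond the scatter), which means that both fluorinated rings shown here, not just the 2-fluorophenyl ring, stand apart from compound 1 by more than the scatter, with compound 1 at the slow-clearance end of the three. Nothing measured here explains why the ring nitrogen makes no readable difference to clearance.

The three compounds cannot separate the contribution of the fluoro from that of the ring nitrogen, and a plain pyridin-3-yl group would be the direct test of whether the nitrogen alone stays close to compound 1 or to compound 3. As far as these compounds go, it also remains open how other groups on the ring at this place, such as a methoxy, a nitrile or an amine, would compare with the fluoro.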